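This account rests on a few compounds, and the source may have more. Where it says the series, first, only, none or still open, it means among the compounds named here.

Measured set in an ADME assay on microsomes from liver (Homo sapiens) for metabolic stability, read by LC-MS, using NADPH, with a stated time of 30 min, tested at 1 uM; a higher number here means faster removal of the compound, a lower number slower removal:
- compound 1, `COCc1ccc(-c2ccc3nnc(C(N)=O)c(N[C@@H](C)C4CCOCC4)c3c2)cn1`, gives 33 mL.min-1.g-1
- compound 2, `COCc1ccc(-c2ccc3nnc(C(N)=O)c(N[C@@H](C)c4ccn(C)n4)c3c2)cn1`, gives 14 mL.min-1.g-1
- compound 3, `C[C@H](Nc1c(C(N)=O)nnc2ccc(-c3ccc(OCCCN(C)C)nc3)cc12)C1CCOCC1`, gives 28 mL.min-1.g-1

Compound 3 stands second highest of the three numbers in this assay. For the measured compounds named here, its step from compound 1 is a 1.2-fold lower number from compound 1 to compound 3 (0.07 log units; within the scatter), so the two are not separated; against compound 2 no single-change step exists, and the two values simply sit within the scatter of each other.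

Compound 4, `C[C@H](Nc1c(C(N)=O)nnc2ccc(-c3ccc(OCCCN(C)C)nc3)cc12)c1ccn(C)n1`, differs from compound 3 by 1-methyl-1H-pyrazol-3-yl in place of oxan-4-yl on a saturated chain carbon bound to a nitrogen on an aromatic ring and a saturated chain carbon. Going by the values given here, the one measured step that bears on this change is the same exchange on the core carrying methoxymethyl, a 2.4-fold lower number from compound 1 to compound 2 (0.37 log units; beyond the scatter), a modest drop beyond the scatter. The other measured step, a 1.2-fold lower number from compound 1 to compound 3 (0.07 log units; within the scatter), changes a different part of the molecule and stays within the scatter, so it gives no reason to expect the exchange to behave differently here.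

The step from compound 3 to compound 4 in this assay is therefore expected to be a modest drop, a 2.3-fold lower number from compound 3 to compound 4 (0.37 log units; beyond the scatter). Compound 4 is estimated at 12 mL.min-1.g-1, with a likely range from 6 mL.min-1.g-1 to 24 mL.min-1.g-1.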

Compound 4, intrinsic clearance in microsomes: 10 mL.min-1.g-1
Compound 4: middle estimate off by 1.2-fold (0.08 log units), on the high side; the range from low to high includes it.
By their numbers in this assay, from the lowest: compounds 4, 2, 3 and 1 (each within the scatter of the next, the first and the last beyond it).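

In this assay the exchange of oxan-4-yl for 1-methyl-1H-pyrazol-3-yl now stands on a second core, with a 2.8-fold lower number from compound 3 to compound 4 (0.45 log units; beyond the scatter), and its size carries over from the core with methoxymethyl to the core with 3-(dimethylamino)propoxy: the same change on two cores in this assay, a 2.4-fold lower number (0.37 log units; beyond the scatter) from compound 1 to compound 2 and a 2.8-fold lower number (0.45 log units; beyond the scatter) from compound 3 to compound 4, 1.2-fold (0.07 log units) apart, within the scatter of two such steps. The change on the aromatic carbon also reads alike with 1-methyl-1H-pyrazol-3-yl in place, where a 1.4-fold lower number from compound 2 to compound 4 (0.15 log units; within the scatter) leaves the two groups unseparated: the same change on two cores in this assay, a 1.2-fold lower number (0.07 log units; within the scatter) from compound 1 to compound 3 and a 1.4-fold lower number (0.15 log units; within the scatter) from compound 2 to compound 4, 1.2-fold (0.07 log units) apart, within the scatter of two such steps. Across these four compounds the two places act independently, and no compound goes against this.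

For the compounds shown here, with only two groups at each place, it stays open which feature of the exchange carries the step. Also open, from the compounds shown here alone, is whether a phenyl ring or a piperidin-4-yl amine on the saturated chain carbon, or a carboxylic acid on the side chain, would follow the same reading.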